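The compounds below may be only part of what the source reports. "The series", "measured", "known", "first", "only" and "open" are said of these compounds alone.

The compounds measured so far:

compound 1, `Cc1ccc(NC(=O)COc2ccc3cc(/C=C4/SC(=O)NC4=O)ccc3c2)cc1`: 1700 nM
compound 2, `O=C(COc1ccc2cc(/C=C3/SC(=O)NC3=O)ccc2c1)Nc1ccc(Br)cc1`: 2900 nM
compound 3, `O=C(COc1ccc2cc(/C=C3/SC(=O)NC3=O)ccc2c1)Nc1cc(Cl)cc(C(F)(F)F)c1`: 4000 nM

All three were tested in an assay on isolated protein for inhibition of histone deacetylase 4 (Homo sapiens), with a stated time of 1 h; on this read-out lower numbers stand for stronger inhibition and higher numbers for weaker inhibition. Among the compounds with values here, compound 3 gives the highest of the three numbers, but only one of its steps is beyond the scatter: a 2.4-fold higher number from compound 1 to compound 3 (0.37 log units; beyond the scatter), while a 1.4-fold higher number from compound 2 to compound 3 (0.14 log units; within the scatter). The three compounds differ only in the aryl group on the amide-type nitrogen, and every step among them is small: a 1.7-fold higher number from compound 1 to compound 2 (0.23 log units; within the scatter), in addition to the two just named.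

Compound 4, `O=C(COc1ccc2cc(/C=C3/SC(=O)NC3=O)ccc2c1)Nc1c(F)cc(F)cc1Br`, continues this series: 2-bromo-4,6-difluorophenyl in place of 3-chloro-5-(trifluoromethyl)phenyl on an amide-type nitrogen. Since the measured changes of the aryl group on the amide-type nitrogen all moved this assay by small amounts, the same is expected here, with no step beyond the scatter in either direction. The estimated step is a 1.1-fold lower number from compound 3 to compound 4 (0.06 log units; within the scatter). Compound 4 is therefore expected to give about 3500 nM in this assay, with a range from 1700 nM to 7500 nM.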

Compound 4, half-maximal inhibitory concentration: 1100 nM
The estimate for compound 4 lay 3.2-fold (0.50 log units) above the measured number; the measured number lies below the stated range.
By their numbers in this assay, from the lowest: compounds 4, 1, 2 and 3 (each within the scatter of the next, the first and the last beyond it).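

On the amide-type nitrogen, 2-bromo-4,6-difluorophenyl shows that a change at this position can take the number in this assay down by more than the scatter, with a 3.6-fold lower number from compound 3 to compound 4 (0.56 log units; beyond the scatter) and a 2.6-fold lower number from compound 2 to compound 4 (0.42 log units; beyond the scatter). Compound 1 goes against any clear gain for the new group, since a 1.5-fold lower number from compound 1 to compound 4 (0.19 log units; within the scatter) leaves the 4-methylphenyl and 2-bromo-4,6-difluorophenyl compounds unseparated, so the position's measured range is still narrow. No measurement presented here bears on why the entering group shifts the number in this way.

The step to compound 4 changes several ring substituents at once, so the compounds shown leave open whether the bromine or the two fluorines matter more on their own. They also leave open how this assay responds when the aryl group carries an amine or a carboxylic acid, or gives way to a longer chain.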